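Pyrazine carboxamide series: the methyl step and compound 4

This account rests on a few compounds, and the source may have more. Where it says the series, first, only, none or still open, it means among the compounds named here.

Compound 2 `O=C(Nc1ccc(Br)c2cccnc12)c1cnccn1` is the parent of the pair on the first core. In a functional assay on BXPC-3 cells (Homo sapiens) for inhibition, read by MTT assay, with a stated time of 72 h (a lower number here means a stronger inhibitor, a higher number a weaker inhibitor), compound 2 gives 7500 nM. Compound 1 `Cc1cnc(C(=O)Nc2ccc(Br)c3cccnc23)cn1` carries the change (methyl in place of hydrogen on an aromatic carbon); for compound 1 the assay reports only a limit, > 10000 nM, not a number. The step therefore reads an at least 1.3-fold higher number from compound 2 to compound 1 (0.12 log units; that floor lies within the scatter), its floor set by the limit of > 10000 nM in this assay, at which 1 of the 3 values shown sits. Compound 3 `CC(C)(C)OC(=O)NCCOc1cc(NC(=O)c2cnccn2)c2ncccc2c1` stands on a second core; the difference between the two cores is not broken down here. In this assay compound 3 gives 9170 nM, which lies beside the parent value within the usual scatter. Compound 4 `Cc1cnc(C(=O)Nc2cc(OCCNC(=O)OC(C)(C)C)cc3cccnc23)cn1` is not yet measured and differs from compound 3 by methyl in place of hydrogen on an aromatic carbon, the same change as the earlier one, at a place described in identical words. The expected step is a 1.6-fold higher number from compound 3 to compound 4 (0.21 log units; within the scatter), which rests on the earlier at least 1.3-fold higher number from compound 2 to compound 1 (0.12 log units; that floor lies within the scatter). Since the starting point already sits close to the ceiling, a reported limit rather than a number is quite likely. Compound 4 is therefore expected to give about 15000 nM, with a likely range from 7000 nM to 40000 nM.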

Compound 4, half-maximal inhibitory concentration: 3670 nM
Compound 4: middle estimate off by 4.1-fold (0.61 log units), on the high side; the measured number lies below the stated range.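

In this assay the change from pyrazin-2-yl to 5-methylpyrazin-2-yl gives a 2.5-fold lower number from compound 3 to compound 4 (0.40 log units; beyond the scatter), so the earlier step on the first core does not carry over to the second, and the two steps differ: the same change on two cores in this assay, an at least 1.3-fold higher number (0.12 log units; that floor lies within the scatter) from compound 2 to compound 1 and a 2.5-fold lower number (0.40 log units; beyond the scatter) from compound 3 to compound 4, at least 3.3-fold (0.52 log units) apart, beyond the scatter of two such steps. From the compounds shown here alone, compound 1 stands at a limit and not at a number, so the earlier step is only a floor and its true size stays unknown: the limit of > 10000 nM in this assay, at which 1 of the 4 values shown sits. With one pair on each core, the data do not show which difference between the cores goes with the opposite outcome, nor how the change would behave on any further core.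

Open, going by these compounds, is whether the lower number survives with a free amine or a carboxylic acid in place of the tert-butyl carbamate at the end of the chain. Also open, on these data alone, is whether an ethyl group or a chlorine atom in place of the methyl gives a step of similar size on either core.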